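Iodo in Place of Chloro: From Compound 2 to Compound 3

The source may report more compounds than this note shows. Statements on the series, on what has been measured and on what is new or still open speak of the compounds shown alone.

Two compounds have so far been measured in a functional assay on T98G cells (Homo sapiens) for cytotoxicity, read by MTT assay, with a stated time of 48 h; a higher number here means a weaker inhibitor, a lower number a stronger inhibitor:

Compound 1, `CC(=NNC(=S)Nc1ccc(Cl)cc1)c1ccccn1`, gives 5.9 nM.
Compound 2, `C/C(=N\NC(=S)Nc1ccc(Cl)cc1)c1ccccn1`, gives 5.9 nM.

The two structures share every atom and bond, and the only drawn difference is the configuration of one double bond. The step of no change at the digits printed from compound 1 to compound 2 (within the scatter) is consistent with the fact that one of compounds 1 and 2 is drawn with a defined configuration and the other without, at the place where they differ, since the same drawn molecule appears in both. Compound 2 therefore stands level with compound 1 in this assay, and the two values cannot be placed in any order.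

Compound 3, `C/C(=N\NC(=S)Nc1ccc(I)cc1)c1ccccn1`, differs from compound 2 by iodo in place of chloro on an aromatic carbon. Among the compounds with values here, no measured step touches this part of the molecule: the only step in hand concerns the drawn configuration, and it carried no change beyond the scatter. There is thus no measured basis for expecting a shift in this assay in either direction, and the expectation for compound 3 rests on compound 2 alone. The step of a 1.0-fold higher number from compound 2 to compound 3 (0.01 log units; within the scatter) is expected to be small. For compound 3 the estimate is 6 nM, within 2 nM to 18 nM.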

Compound 3, half-maximal inhibitory concentration: 64 nM
Compound 3: middle estimate off by 11-fold (1.03 log units), on the low side, and the stated range ends below it.
By their numbers in this assay, from the lowest: compounds 1 and 2 (each within the scatter of the next); then compound 3.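

In this assay, this position turns out to be sensitive to the group it carries: an 11-fold higher number from compound 2 to compound 3 (1.04 log units; beyond the scatter), although the exchange of chloro for iodo replaces one heavy atom with one heavy atom and neither group counts a hydrogen-bond donor or acceptor. The earlier pair differed only in how a double bond was drawn and said nothing about this place, on an aromatic carbon of a six-membered aromatic ring of carbon only, para to a large group; the present pair shows that a single-atom exchange there is enough to produce a large step, with chloro on the stronger side. Nothing in hand explains why the iodo compound gives the higher number, since the only available observation concerns the drawn configuration and has no bearing on this exchange.

The compounds shown leave open how fluoro, bromo, a plain hydrogen or an amine would read at this same place, and so whether the numbers follow any order across such groups. Within the data shown here, with only two groups compared at this position, they also leave open whether chloro is unusually favourable or iodo unusually poor.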